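This account rests on a few compounds, and the source may have more. Where it says the series, first, only, none or still open, it means among the compounds named here.

Compound 1 `COc1ccc(CN2C(=O)/C(=C\c3cc(OC)c(OC)c(OC)c3)c3ccccc32)cc1` gives 2700 nM 
Compound 2 `COc1cc(/C=C2/C(=O)N(C)c3ccc(O)cc32)cc(OC)c1OC` gives 2800 nM 

In a functional assay on cells (Cancer cell lines, Homo sapiens) for cytotoxicity, with a stated time of 48 h (on this read-out lower numbers stand for stronger inhibition of growth and higher numbers for weaker inhibition of growth), compound 2 gives 2800 nM and so stands level with compound 1, within the usual scatter. Compound 3 `COc1ccc2c(c1)/C(=C\c1cc(OC)c(OC)c(OC)c1)C(=O)N2C` differs from compound 2 by one change (methyl in place of hydrogen on an oxygen on an aromatic ring): methyl in place of hydrogen on an oxygen on an aromatic ring, which turns hydroxy into methoxy. Going by the values given here, no measured pair shows this change, so any expectation is loose. A modest move towards a lower number in this assay is expected, only slightly beyond the scatter. The estimated step is a 1.9-fold lower number from compound 2 to compound 3 (0.27 log units; within the scatter) in this read-out. For compound 3 the expected value is 1500 nM with an estimated range from 350 nM to 6000 nM in this read-out.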

Compound 3, concentration for 50% growth inhibition: 2600 nM
Compound 3: the middle estimate sits 1.7-fold (0.24 log units) below what was measured; the measured number falls inside the stated range.
By their numbers in this assay, from the lowest: compounds 3, 1 and 2 (each within the scatter of the next).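

In this assay, turning hydroxy into methoxy, with methyl in place of hydrogen on an oxygen on an aromatic ring, comes to a 1.1-fold lower number from compound 2 to compound 3 (0.03 log units; within the scatter). At this position, then, the read-out does not tell the two groups apart, so the hydrogen on that oxygen is not needed to keep this level of growth inhibition. Nothing available bears on the reason for this result.

From the compounds shown here alone, whether an ethyl group or a longer chain on that oxygen, or an amine or a carboxylic acid at this place on the ring, would read the same stays open. This single pair also cannot say whether the same swap would behave alike on another core.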